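Trichloromethyl for methyl on a sulfonamide-bearing five-membered ring

A few compounds are considered here, and "the series" means these few. Any claim that something is new, unique, unknown or untested is made for them only; others in the source may bear on it.

Of the compounds shown here, three have been measured in a physicochemical assay for lipophilicity; a higher number here means a more lipophilic compound, a lower number a more polar compound. Compound 1 `CN1C=CN(C2NC(C(Cl)(Cl)Cl)=CN2c2ccc(S(N)(=O)=O)cc2)C=C1` gives 2.85. Compound 2 `CC1=CN(c2ccc(S(N)(=O)=O)cc2)C(N2C=CN(C)C=C2)O1` gives 1.04. Compound 3 `CC1=CN(c2ccc(S(N)(=O)=O)cc2)C(N2C=CN(C)C=C2)S1` gives 1.75, the second highest of the three numbers: it lies above compound 2 by a margin beyond the scatter, and below compound 1 by a margin beyond the scatter.

Compound 4 `CN1C=CN(C2SC(C(Cl)(Cl)Cl)=CN2c2ccc(S(N)(=O)=O)cc2)C=C1` has not yet been measured. It differs from compound 3 in one place: trichloromethyl in place of methyl on a double-bonded ring carbon. Within the data shown here, no measured pair shows this exact change, so the size of the step must be estimated rather than read off. Compound 1 also carries a trichloromethyl group on its ring, and in this assay compound 1 gives 2.85, which is well above compound 3. The step from compound 3 to compound 4 is therefore expected to be upward and clearly beyond the scatter, estimated at a number 1.15 log units higher from compound 3 to compound 4 (beyond the scatter). Compound 4 is expected to give about 2.9 in this assay, most likely between 2.4 and 3.4.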

Compound 4, partition coefficient: 3.13
The estimate for compound 4 lay 0.23 log units below the measured number; the measured number falls inside the stated range.
By their numbers in this assay, from the lowest: compound 2; then compound 3; then compounds 1 and 4 (each within the scatter of the next).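

In this assay, trichloromethyl in place of methyl on the double-bonded ring carbon next to the ring sulfur gives a number 1.38 log units higher from compound 3 to compound 4 (beyond the scatter), a large step. This is the first pair among these compounds that differs in one place only, so the size of this change at this position can now be read directly instead of being inferred from compounds that differ in more than one place. Nothing measured here explains the size of the step.

Among the compounds shown, this position carries only methyl and trichloromethyl, so what an amine, a carboxylic acid or a longer chain such as ethyl would do here stays open. As far as these compounds go, it also stays open whether the same change gives a step of similar size on the core of compound 2.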